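Beta-lactam series: aryl swap on the saturated ring carbon

The source may hold more compounds than are shown below. What is called first, only, known or untested is meant among the compounds shown, and "the series" means these compounds.

Measured so far:
compound 1 `COc1cc(N2C(=O)[C@@H](Oc3ccccc3)[C@H]2c2cccc([N+](=O)[O-])c2)cc(OC)c1OC` — 30000 nM
compound 2 `COc1ccc([C@@H]2[C@H](Oc3ccccc3)C(=O)N2c2cc(OC)c(OC)c(OC)c2)c([N+](=O)[O-])c1O` — 89000 nM

In a functional assay on MCF7 cells (Homo sapiens) for antiproliferative activity, read by MTT assay, with stated times of 24 h and 72 h (a lower number here means a stronger inhibitor, a higher number a weaker inhibitor), compound 2 stands highest of the two numbers, its nearest neighbour being compound 1 at a 3.0-fold higher number from compound 1 to compound 2 (0.47 log units; beyond the scatter). Compound 3 `COc1cc(N2C(=O)[C@@H](Oc3ccccc3)[C@H]2c2cccc(N)c2)cc(OC)c1OC` differs from compound 2 by a group of 7 heavy atoms (6 carbon, 1 nitrogen; one six-membered aromatic ring of carbon only) in place of a group of 12 heavy atoms (7 carbon, 1 nitrogen, 4 oxygen; one six-membered aromatic ring of carbon only), on a saturated ring carbon. Within the data shown here, the one measured step bears on it only loosely: it was the reverse-direction change on the same saturated ring carbon, a 3.0-fold higher number from compound 1 to compound 2 (0.47 log units; beyond the scatter), which was modest. Among the measured compounds shown here, removing that larger group is therefore expected to pull the number back down rather than raise it; the 3-aminophenyl itself has no measured precedent here. The step from compound 2 to compound 3 is expected to be a 5.9-fold lower number from compound 2 to compound 3 (0.77 log units; beyond the scatter). Compound 3 is estimated at 15000 nM, range 4000 nM to 60000 nM.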

Compound 3, half-maximal inhibitory concentration: 17000 nM
Compound 3: middle estimate off by 1.1-fold (0.05 log units), on the low side; low and high end bracket the measured number.
By their numbers in this assay, from the lowest: compounds 3 and 1 (each within the scatter of the next); then compound 2.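

In this assay, amino in place of nitro on the aromatic ring at this saturated ring carbon gives a 1.8-fold lower number from compound 1 to compound 3 (0.25 log units; within the scatter) and so does not separate the two groups. Among these compounds, the larger group of compound 2 remains the only change here with a step beyond the scatter: the 3-aminophenyl gives a 5.2-fold lower number from compound 2 to compound 3 (0.72 log units; beyond the scatter) and brings the number back to the level of compound 1.

Still open, on these data alone, is which part of the larger group in compound 2 carries that step, and how an acetamide, a dimethylamino group or a carboxylic acid would read on the same aromatic ring. Nothing available gives a reason for either step.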